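A Methoxyphenyl Arm Gives Way to a Fluoropyridyl Arm

The source may report more compounds than this note shows. Statements on the series, on what has been measured and on what is new or still open speak of the compounds shown alone.

Of the compounds shown here, three sharing one core have been tested in a functional assay on KYSE-70 cells for antiproliferative activity against KYSE-70 cell line (Homo sapiens), read by MTT assay, with a stated time of 72 h; a lower number here means a stronger inhibitor, a higher number a weaker inhibitor. Compound 1 `O=C(Nc1ccc(C(F)(F)F)cc1)c1cc(=O)[nH]c2cc(Br)ccc12` reached only the limit of the assay, > 20000 nM. Compound 2 `CC(C)(C)c1ccc(NC(=O)c2cc(=O)[nH]c3cc(Br)ccc23)cc1` likewise stopped at the limit, > 20000 nM. The change between them, a step that the two limits leave unreadable from compound 1 to compound 2, therefore cannot be sized. Compound 3 `COc1ccc(-c2ccc3c(C(=O)Nc4cccc(F)c4)cc(=O)[nH]c3c2)cc1` is no different: in this assay it gave only the limit, > 20000 nM, so it stands at the edge of what the assay can report, with no number of its own. All three results sit at that same edge (the limit of > 20000 nM in this assay, at which 3 of the 3 values shown sit).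

Compound 4 `O=C(Nc1cccc(F)c1)c1cc(=O)[nH]c2cc(-c3cccnc3F)ccc12` differs from compound 3 in one place: 2-fluoropyridin-3-yl in place of 4-methoxyphenyl on an aromatic carbon. Among the compounds with values here, no measured step covers this kind of change, and the single step that exists between measured compounds is unreadable. The expectation is that a number no higher from compound 3 to compound 4 (the limit leaves the size open) stays within the scatter. The estimate for compound 4 is 20000 nM, spanning 6000 nM to 40000 nM, and a limit rather than a number is expected to be the most likely outcome.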

Compound 4, half-maximal inhibitory concentration: > 20000 nM
Compound 4 gave a limit, no number (the forecaster's own chance of this, stated with the estimate: 70%); the middle value sits exactly at the limit.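

Compound 3 and compound 4 both give a limit rather than a number, so the step from 4-methoxyphenyl to 2-fluoropyridin-3-yl cannot be read: the limit of > 20000 nM in this assay, at which 4 of the 4 values shown sit. The compounds shown leave open which change to the shared core, if any, would give an actual number in this assay.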